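A few compounds are considered here, and "the series" means these few. Any claim that something is new, unique, unknown or untested is made for them only; others in the source may bear on it.

Measured compounds:

- compound 1 `COc1ccc([C@H]2CC(=O)N(C(=O)c3ccccc3)C2)cc1OC1CCCC1` — in a functional assay on HEK293 cells (Homo sapiens) for cytotoxicity (on this read-out lower numbers stand for higher toxicity in this test and higher numbers for lower toxicity in this test), compound 1 gives only the assay limit, > 10000 nM.
- compound 2 `COc1ccc([C@H]2CC(=O)N(c3ccc(C)cc3)C2)cc1OC1CCCC1` — in this assay compound 2 likewise gives only the assay limit, > 10000 nM.
- compound 3 `COc1ccc([C@H]2CC(=O)N(c3ccccc3C(F)(F)F)C2)cc1OC1CCCC1` — in this assay compound 3 also gives only the assay limit, > 10000 nM.

Compound 1 therefore stands at the limit, and no number places it relative to the others. The steps between the measured compounds are all unreadable for the same reason: a step that the two limits leave unreadable from compound 1 to compound 2, a step that the two limits leave unreadable from compound 1 to compound 3 and a step that the two limits leave unreadable from compound 2 to compound 3 all sit at the ceiling of the read-out, as summarised by the limit of > 10000 nM in this assay, at which 3 of the 3 values shown sit. Among the measured compounds shown here, nothing so far separates one substituent on the amide-type nitrogen in the ring from another.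

The unmeasured compound 4 `COc1ccc([C@H]2CC(=O)N(c3cccnc3)C2)cc1OC1CCCC1` carries the change (pyridin-3-yl in place of benzoyl on an amide-type nitrogen in a ring). For the measured compounds named here, the steps that bear on it are the three above, and each of them leaves the size unreadable; they show only that three different groups at that position all remain outside the measurable range. On that basis no step beyond the scatter is expected in this assay, and the expected outcome for compound 4 is again a value at the limit, a step that the limit leaves unreadable from compound 1 to compound 4. The estimate for compound 4 is 15000 nM, within 8000 nM to 40000 nM, with a high chance that only a limit is reported.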

Compound 4, half-maximal cytotoxic concentration: > 10000 nM
Compound 4 ended at the assay's limit (the forecaster's own chance of this, stated with the estimate: 85%); the middle value lies beyond the limit too.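

Compound 4, like compound 1, compound 2 and compound 3, gives only an assay limit and no number in this assay and no step among these compounds can be read: the limit of > 10000 nM in this assay, at which 4 of the 4 values shown sit.

The compounds shown leave open whether any substituent on the amide-type nitrogen in the ring gives a measurable value in this read-out, and how these substituents differ.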